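The source may report more compounds than this note shows. Statements on the series, on what has been measured and on what is new or still open speak of the compounds shown alone.

Measured so far in an ADME assay on HEK293 cells (Homo sapiens) for cytotoxicity, read by resazurin assay, with a stated time of 48 h; on this read-out higher numbers stand for lower toxicity in this test and lower numbers for higher toxicity in this test:

- compound 1 `Cc1cccc(S(=O)(=O)Nc2ccc3oc(-c4ccccc4)nc3c2)c1` gives 69000 nM
- compound 2 `CS(=O)(=O)Nc1ccc2oc(-c3ccccc3)nc2c1` gives a limit of this assay only, > 100000 nM
- compound 3 `Cc1ccc(S(=O)(=O)Nc2ccc3oc(-c4ccccc4)nc3c2)cc1` gives 75000 nM

Compound 3 holds the highest of the two numbers; its nearest neighbour is compound 1, the gap a 1.1-fold higher number from compound 1 to compound 3 (0.04 log units; within the scatter) lying within the scatter. Compound 2 sits at the limit (the limit of > 100000 nM in this assay, at which 1 of the 3 values shown sits). The step of an at least 1.3-fold lower number from compound 2 to compound 3 (0.12 log units; that floor lies within the scatter) therefore gives only a floor. Compound 4 `O=S(=O)(Nc1ccc2oc(-c3ccccc3)nc2c1)c1cccc(Cl)c1` is not yet measured and differs from compound 3 as 3-chlorophenyl in place of 4-methylphenyl on a sulfonyl sulfur. Both measured steps change the group on the sulfonyl sulfur and stay within the scatter; none involves a 3-chlorophenyl. In this assay no step beyond the scatter is expected, and compound 4 is estimated at 70000 nM, between 30000 nM and 150000 nM. The expected step of a 1.1-fold lower number from compound 3 to compound 4 (0.03 log units; within the scatter) lies within the scatter.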

Compound 4, half-maximal cytotoxic concentration: 70000 nM
Compound 4: the middle estimate sits on the measured number at the digits printed; low and high end bracket the measured number.
By their numbers in this assay, from the lowest: compounds 1, 4 and 3 (each within the scatter of the next). At a limit, above all of these: compound 2.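

In this assay, 3-chlorophenyl in place of 4-methylphenyl on a sulfonyl sulfur gives a 1.1-fold lower number from compound 3 to compound 4 (0.03 log units; within the scatter), so a chlorine-bearing group is now covered at this position. The direct exchange of chloro for methyl on an aromatic carbon gives a 1.0-fold higher number from compound 1 to compound 4 (0.01 log units; within the scatter). The comparison with methyl on the sulfur gives only a floor, an at least 1.4-fold lower number from compound 2 to compound 4 (0.15 log units; that floor lies within the scatter), because compound 2 stands at a limit: the limit of > 100000 nM in this assay, at which 1 of the 4 values shown sits.

Open, going by these compounds, is whether an amine or a carboxylic acid in place of chloro would give a step beyond the scatter.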